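Chloro added to the pyridazine of a piperazine urea

This account rests on a few compounds, and the source may have more. Where it says the series, first, only, none or still open, it means among the compounds named here.

Compound 3 `Cc1ccnnc1N1CCN(C(=O)Nc2ccc(C(C)(C)C)cc2)[C@H](C)C1` gives 8.5 nM in an assay on HEK293 cells for inhibition of transient receptor potential cation channel subfamily V member 1 (Homo sapiens), read by FLIPR (a higher number here means a weaker inhibitor, a lower number a stronger inhibitor), the lowest of the two numbers recorded. Compound 2 `Cc1cnnc(N2CCN(C(=O)Nc3ccc(C(C)C)cc3)CC2)c1` gives 5020 nM in this assay, a weaker result that lies well beyond the scatter. For compound 1 `Cc1cc(N2CCN(C(=O)Nc3nc4ccc(F)cc4s3)CC2)nnc1Cl` this assay reports only a limit, > 10000 nM. Compound 4 `Cc1cc(Cl)nnc1N1CCN(C(=O)Nc2ccc(C(C)(C)C)cc2)[C@H](C)C1` differs from compound 3 by chloro in place of hydrogen on an aromatic carbon. Going by the values given here, no measured pair isolates this change, and compound 1 differs from compound 3 in more than one place, so its limit settles nothing here. The expected change is modest, a 1.6-fold higher number from compound 3 to compound 4 (0.22 log units; within the scatter), likely within the usual scatter or a slight loss. Compound 4 is estimated at 14 nM, with a range of 4 nM to 50 nM.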

Compound 4, half-maximal inhibitory concentration: 10 nM
Compound 4: the middle estimate sits 1.4-fold (0.15 log units) above what was measured, and the stated range covers the measured number.
By their numbers in this assay, from the lowest: compounds 3 and 4 (each within the scatter of the next); then compound 2. At a limit, above all of these: compound 1.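

In this assay, going from 4-methylpyridazin-3-yl to 6-chloro-4-methylpyridazin-3-yl gives a 1.2-fold higher number from compound 3 to compound 4 (0.07 log units; within the scatter), so this aromatic carbon takes a chloro in place of hydrogen with no change that can be told from the scatter. Going by these compounds alone, this is the only measured pair that isolates the change, and it shows the chloro is tolerated alongside the tert-butyl-substituted urea of compound 3. Nothing measured here offers a reason for this result.

Going by these compounds, it remains open whether a methoxy group, an amine or a nitrile at this position would be tolerated equally. On these data alone, whether the chloro would behave the same way on a different urea also remains unknown.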